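Trifluoromethyl on compound 3: working notes on cytotoxicity

A few compounds are considered here, and "the series" means these few. Any claim that something is new, unique, unknown or untested is made for them only; others in the source may bear on it.

In an ADME assay on MDBK cells (Bos taurus) for cytotoxicity, read by MTT assay, with a stated time of 72 h (on this read-out higher numbers stand for lower toxicity in this test and lower numbers for higher toxicity in this test), compound 3 (`Cc1ccc(-c2nn(-c3ccccc3)cc2CNc2ccccc2)cc1`) gives > 100000 nM as its result, which is a limit of the assay and not a number. Compound 1 (`Cc1ccc(-c2nn(-c3ccccc3)cc2CNc2ccc(Br)cc2)cc1`) gives > 100000 nM as its result, also a limit. Compound 3 thus stands with compound 1 at the limit of > 100000 nM in this assay, at which 2 of the 3 values shown sit, and cannot be ranked against it.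

Compound 4 (`Cc1ccc(-c2nn(-c3ccccc3)cc2CNc2ccc(C(F)(F)F)cc2)cc1`) differs from compound 3 by trifluoromethyl in place of hydrogen on an aromatic carbon with trifluoromethyl in place of hydrogen on an aromatic carbon, para to a large group. For the measured compounds named here, the only measured step at that carbon is a step that the two limits leave unreadable from compound 1 to compound 3 and it gives no usable size. The nearest guide is compound 2 (`FC(F)(F)c1ccc(NCc2cn(-c3ccccc3)nc2-c2ccc(Cl)cc2)cc1`), which carries the same 4-(trifluoromethyl)phenyl but differs from compound 4 elsewhere. Compound 2 reads 31000 nM as a true number. A move toward lower numbers, meaning higher toxicity, is therefore expected, though a further limit result remains possible. The estimated step is an at least 1.6-fold lower number from compound 3 to compound 4 (0.22 log units; that floor lies within the scatter) in this assay and its size stays loose. For compound 4 the expected value is 60000 nM with an estimated range from 25000 nM to 100000 nM in this assay.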

Compound 4, half-maximal cytotoxic concentration: > 100000 nM
Compound 4 ended at the assay's limit; the forecaster's own chance of this, stated with the estimate: 45%; middle value at least 1.6-fold (0.22 log units) away from the limit.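

In this assay compound 4 gives > 100000 nM, which is a limit of the assay and not a number. Hydrogen, bromo and trifluoromethyl at this carbon cannot be ranked, and the steps among compound 1, compound 3 and compound 4 cannot be read, as all three compounds sit at one limit: the limit of > 100000 nM in this assay, at which 3 of the 4 values shown sit.

For the compounds shown here, the one readable step is an at least 3.2-fold higher number from compound 2 to compound 4 (0.50 log units; beyond the scatter), for methyl in place of chloro on an aromatic carbon, so 4-(trifluoromethyl)phenyl alone does not bring a true number.

Open, as far as these compounds go, is whether an amine or a carboxylic acid at this carbon, para to a large group, would bring the read-out off the limit. Also open, from the compounds shown here alone, is whether methyl in place of chloro would give a readable change in a pair carrying hydrogen or bromo at that carbon.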